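The source may report more compounds than this note shows. Statements on the series, on what has been measured and on what is new or still open speak of the compounds shown alone.

Measured so far:
- compound 1, `COc1ccc(N2C(=O)NC3(CSC4=C3C(=O)c3ncccc3C4=O)C2=O)cc1`: 70 nM
- compound 2, `O=C1NN(c2ccc(Cl)cc2)C(=O)C2(CSC3=C2C(=O)c2ncccc2C3=O)N1`: 150 nM

Compound 1 has the lowest of the two numbers in a functional assay on MT4 cells (Homo sapiens) for antiproliferative activity, read by MTT assay, with a stated time of 96 h (a higher number here means a weaker inhibitor, a lower number a stronger inhibitor), with 70 nM. Among the compounds with values here, the only other compound, compound 2, gives 150 nM in this assay, a higher number lying beyond the usual scatter, so compound 1 is the stronger inhibitor of the pair. Compound 2 differs from compound 1 in more than one place, so the gap between them cannot be assigned to any single change.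

Compound 3, `CC(C)(C)c1ccc(N2C(=O)NC3(CSC4=C3C(=O)c3ncccc3C4=O)C2=O)cc1`, keeps the core of compound 1 and differs from it in one place:

tert-butyl in place of methoxy on an aromatic carbon

Within the data shown here, no step between measured compounds covers this change, so there is nothing to anchor it. With no such anchor, the expected step from compound 1 to compound 3 is small, a 1.4-fold higher number from compound 1 to compound 3 (0.15 log units; within the scatter), in the direction of a slightly higher number and possibly none beyond the scatter. Compound 3 is accordingly estimated at 100 nM in this assay, with a range of 35 nM to 300 nM.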

Compound 3, half-maximal inhibitory concentration: 200 nM
Compound 3: the middle estimate sits 2.0-fold (0.30 log units) below what was measured, and the stated range covers the measured number.
By their numbers in this assay, from the lowest: compound 1; then compounds 2 and 3 (each within the scatter of the next).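

In this assay, replacing methoxy with tert-butyl, on an aromatic carbon para to a large group, gives a 2.9-fold higher number from compound 1 to compound 3 (0.46 log units; beyond the scatter). Within the data shown here, this is the first step that can be tied to one place, and it shows that the number responds to the group held there, though modestly, with compound 3 still at 200 nM in the nanomolar range. The change swaps 2 heavy atoms for 4 and loses the 1 hydrogen-bond acceptor of methoxy, but these differences travel together in this single pair, and nothing measured here accounts for the step.

The compounds shown leave open how a hydroxyl, an amine, a carboxylic acid or a plain hydrogen at this place would read, and so whether the step tracks the heavy-atom count, the acceptor or neither. They also leave open whether the same replacement would give a step of like size on the core of compound 2.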